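A few compounds are considered here, and "the series" means these few. Any claim that something is new, unique, unknown or untested is made for them only; others in the source may bear on it.

In an ADME assay for permeability, using PAMPA, with a stated time of 4 h, at pH 7.4, tested at 100 uM (a higher number here means that the compound crosses the layer faster, a lower number that the compound crosses the layer more slowly), three compounds have been measured so far.

Compound 1 `Cc1nc2cc(-c3cccc(Oc4ccccc4)c3)nn2c(-c2cc(F)c3c(c2C)CCCO3)c1C(OC(C)(C)C)C(=O)O` gives 472 nm/s
Compound 2 `Cc1nc2cc(-c3cccc(-c4ccccc4)c3)nn2c(-c2cc(F)c3c(c2C)CCCO3)c1[C@H](OC(C)(C)C)C(=O)O` gives 733 nm/s
Compound 3 `Cc1nc2cc(-c3cccc(OCc4ccccc4)c3)nn2c(N2CCC(C)(C)CC2)c1C(OC(C)(C)C)C(=O)O` gives 375 nm/s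

Compound 2 at 733 nm/s stands within the usual scatter of the other two values, so the three cannot be put in order. Compound 4 `Cc1nc2cc(-c3cccc(-c4ccccc4F)c3)nn2c(-c2cc(F)c3c(c2C)CCCO3)c1[C@H](OC(C)(C)C)C(=O)O` has not yet been measured. It differs from compound 2 by fluoro in place of hydrogen on an aromatic carbon, which turns a phenyl into a 2-fluorophenyl. For the measured compounds named here, no two measured compounds differ in only one place, so the data give no direct measure of such a step. Compound 1 at 472 nm/s and compound 3 at 375 nm/s differ from compound 2 in more than this one place and still fall within the scatter of it, so no step beyond the scatter is expected in this assay in either direction. The expected change is the estimated 1.0-fold lower number from compound 2 to compound 4 (0.01 log units; within the scatter) and it stays within the scatter. For compound 4 the estimated value is 720 nm/s with an expected range from 380 nm/s to 1250 nm/s in this measurement.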

Compound 4, apparent permeability: 608 nm/s
Compound 4: middle estimate off by 1.2-fold (0.07 log units), on the high side; low and high end bracket the measured number.
By their numbers in this assay, from the lowest: compounds 3, 1, 4 and 2 (each within the scatter of the next).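

For the compounds shown here, compound 4 supplies the first comparison in this set in which only one place differs: in this assay fluoro in place of hydrogen on an aromatic carbon, ortho to a large group, gives a 1.2-fold lower number from compound 2 to compound 4 (0.08 log units; within the scatter) and so stays within the scatter. Turning the phenyl of compound 2 into the 2-fluorophenyl of compound 4 therefore produces no step that this read-out can distinguish from repeat measurement. Nothing shown explains this result.

On these data alone, it remains open whether a larger group at the same place, such as trifluoromethyl, methoxy or an amine, would give a step beyond the scatter. Also open, as far as these compounds go, is whether fluoro would read the same way elsewhere on the ring, or on the structures of compound 1 and compound 3.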